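The compounds below may be only part of what the source reports. "The series", "measured", "known", "first", "only" and "open" are said of these compounds alone.

The measured compounds and their values in a functional assay on HCT-15 cells (Homo sapiens) for inhibition, read by sulforhodamine B assay; a lower number here means a stronger inhibitor of growth, a higher number a weaker inhibitor of growth:

compound 1, `O=C(CCC1=CCCN(CCCCc2ccc(-c3ccccc3)cc2)C1=O)NO`: 4560 nM
compound 2, `O=C(CCC1=CCCN(Cc2ccc(F)cc2)C1=O)NO`: 9960 nM

Of the two compounds measured, compound 2 gives the higher number in this assay; compound 1 sits below it by a gap that lies beyond the usual scatter, so compound 2 is the weaker inhibitor of growth among these two. Both share the same core, a hydroxamic acid chain on an unsaturated lactam whose nitrogen carries a benzyl-type arm; they differ only in what that arm carries.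

The step under consideration goes from compound 2 to compound 3, `O=C(CCC1=CCCN(Cc2ccc(NC(=O)c3ccccc3)cc2)C1=O)NO`. The change is benzamido in place of fluoro on an aromatic carbon. Among the compounds with values here, nothing measured here tells directly how such a change plays out, so any expectation rests on the one comparison available: compound 1, with its larger arm, gives 4560 nM, a lower number than compound 2. On that basis a modest lowering of the number is expected, a 2.8-fold lower number from compound 2 to compound 3 (0.45 log units; beyond the scatter), though one not far outside the scatter. Compound 3 is therefore estimated at 3500 nM, with a range from 1200 nM to 10000 nM.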

Compound 3, concentration for 50% growth inhibition: > 10000 nM
Compound 3: no number, only a limit; the forecaster's own chance of this, stated with the estimate: 5%; middle value at least 2.8-fold (0.45 log units) from the limit.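

In this assay, compound 3 gives no number, only a limit of > 10000 nM. Placing benzamido in place of fluoro, on an aromatic carbon para to a large group, gives a number no lower from compound 2 to compound 3 (the limit leaves the size open), so this position does not turn a much bigger substituent, with its extra aromatic ring, amide hydrogen and carbonyl, into a lower number. The result therefore marks a boundary rather than a place on a scale, and it adds to the two earlier numbers only a floor for this one change: the limit of > 10000 nM in this assay, at which 1 of the 3 values shown sits.

From the compounds shown here alone, how far compound 3 lies past that limit stays open, so the step cannot say whether benzamido costs little or much relative to fluoro, and nothing separates the part played by the amide link from that of the terminal aromatic ring. Equally open, going by these compounds, is how an amine, an acetamido group or a plain phenyl ring at the same place would read in this assay, and whether a longer chain carrying the benzamido-bearing ring would change the outcome.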